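A few compounds are considered here, and "the series" means these few. Any claim that something is new, unique, unknown or untested is made for them only; others in the source may bear on it.

Measured so far in a functional assay on PC-3 cells (Homo sapiens) for cytotoxicity, read by sulforhodamine B assay, with a stated time of 48 h; a lower number here means a stronger inhibitor, a higher number a weaker inhibitor:
- compound 1 `COc1ccc(C2CC(c3cccc4ccccc34)=NN2C(C)=O)c(OC)c1OC` gives 1220 nM
- compound 2 `COc1cc(C2CC(c3cccc4ccccc34)=NN2C(C)=O)ccc1O` gives 2130 nM
- compound 3 `O=CCN1N=C(c2ccc3ccccc3c2)CC1c1ccccc1` gives 7400 nM

Among these three, compound 3 has the highest number in this assay, and its distance to both compound 2 and compound 1 lies beyond the scatter, so compound 3 is the weakest inhibitor of the set. Compound 4 `O=CCN1N=C(c2ccc3ccccc3c2)CC1c1ccccc1[N+](=O)[O-]` has not yet been measured. It differs from compound 3 in one place: nitro in place of hydrogen on an aromatic carbon. Going by the values given here, no step between two measured compounds isolates this kind of change, so nothing in the set fixes its size or direction. In the absence of such a step, the expectation is a step in this assay that does not clearly exceed the scatter, with either direction possible and the larger room lying toward a somewhat lower number. The estimated step from compound 3 to compound 4 is therefore a 1.5-fold lower number from compound 3 to compound 4 (0.17 log units; within the scatter). Compound 4 is expected to give about 5000 nM, within a range from 1500 nM to 16000 nM.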

Compound 4, half-maximal inhibitory concentration: 3010 nM
Estimate against measurement, compound 4: 1.7-fold (0.22 log units) above; measured number inside the range.
By their numbers in this assay, from the lowest: compounds 1, 2 and 4 (each within the scatter of the next, the first and the last beyond it); then compound 3.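

In this assay, going by these compounds alone, the change from phenyl to 2-nitrophenyl gives a 2.5-fold lower number from compound 3 to compound 4 (0.39 log units; beyond the scatter) and is the first step in the set that isolates a single change, so it gives this kind of change both a size and a direction. At this aromatic carbon, ortho to a large group, the nitro group therefore goes with a stronger inhibitor than hydrogen, though this rests on one pair of compounds. Nothing available accounts for the size or direction of this step.

The compounds shown leave open whether an amine or a carboxylic acid on the same carbon would move the number as far as nitro does. They also leave open whether nitro would give a similar step elsewhere on this ring or on the core of compound 1.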